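A few compounds are considered here, and "the series" means these few. Any claim that something is new, unique, unknown or untested is made for them only; others in the source may bear on it.

In a functional assay on SGC-7901 cells (Homo sapiens) for antiproliferative activity, read by MTT assay, with a stated time of 72 h (a lower number here means a stronger inhibitor, a higher number a weaker inhibitor), compound 1 (`CCOC(=O)c1cc(-c2cc(OC)c(OC)c(OC)c2)c(-c2ccc(OC)cc2)s1`) gives 9760 nM and compound 2 (`COc1ccc(-c2sc(C(=O)O)cc2-c2cc(OC)c(OC)c(OC)c2)cc1`) gives 7800 nM, so compound 2 stands level with compound 1 within the scatter. Compound 3 (`COc1ccc(-c2sccc2-c2cc(OC)c(OC)c(OC)c2)cc1`) carries hydrogen in place of carboxy on an aromatic carbon. Going by the values given here, one measured step bears on this place, a 1.3-fold lower number from compound 1 to compound 2 (0.10 log units; within the scatter), with hydrogen in place of ethyl on an oxygen next to a carbonyl group. That step kept the carboxy carbon, whereas this change removes the whole group, so the guide is weak. The expected step in this assay is a 1.6-fold lower number from compound 2 to compound 3 (0.19 log units; within the scatter), which is no change beyond the scatter. Compound 3 is estimated at 5000 nM, with an expected range of 800 nM to 15000 nM.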

Compound 3, half-maximal inhibitory concentration: 5470 nM
For compound 3 the middle estimate is 1.1-fold (0.04 log units) below the measured one, and the stated range covers the measured number.
By their numbers in this assay, from the lowest: compounds 3, 2 and 1 (each within the scatter of the next).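

Compound 3 shows that this carbon next to the ring sulfur need not carry any carbonyl-bearing group at all in this assay: losing the carboxy group leaves the compounds level (a 1.4-fold lower number from compound 2 to compound 3 (0.15 log units; within the scatter)). Losing the whole ethoxycarbonyl group also stays within the scatter (a 1.8-fold lower number from compound 1 to compound 3 (0.25 log units; within the scatter)), so ester, acid and hydrogen stand level at this place on the shared core. Nothing available explains this result. As far as these compounds go, whether an amine, a primary amide or a longer chain on this carbon would also stand level remains open.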